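Three Probes and a Shortened Chain Against Hexokinase-3

A few compounds are considered here, and "the series" means these few. Any claim that something is new, unique, unknown or untested is made for them only; others in the source may bear on it.

Three measured compounds share one core and carry an ((iodomethyl)carbonyl)amino group at the far end of a chain. Compound 1 `O=C(CI)NCCCCCCCCNc1ncnc2c1ncn2[C@@H]1O[C@H](COP(=O)(O)OP(=O)(O)OP(=O)(O)O)[C@@H](O)[C@H]1O` has a plain saturated chain, while compound 2 `O=C(CI)NCCCCCC(=O)NCCCCNc1ncnc2c1ncn2[C@@H]1O[C@H](COP(=O)(O)OP(=O)(O)OP(=O)(O)O)[C@@H](O)[C@H]1O` and compound 3 `O=C(CI)NCCCCCCC(=O)NCCCNc1ncnc2c1ncn2[C@@H]1O[C@H](COP(=O)(O)OP(=O)(O)OP(=O)(O)O)[C@@H](O)[C@H]1O` differ from it in the makeup of that chain. In an assay on isolated protein for inhibition of hexokinase-3 (Rattus norvegicus), with a stated time of 6 h, tested at 10 mM (a lower number here means less inhibition, a higher number more inhibition at the concentration tested (going by the name of the read-out)), compound 1 gives 47%, compound 2 gives 0% and compound 3 gives 0%. Compound 1 thus stands highest of the three, and both other compounds lie below it by more than the usual scatter. Compound 4 `O=C(CI)NCCCCCCCNc1ncnc2c1ncn2[C@@H]1O[C@H](COP(=O)(O)OP(=O)(O)OP(=O)(O)O)[C@@H](O)[C@H]1O` is not yet measured; it differs from compound 1 in one place: ((iodomethyl)carbonyl)amino in place of (((iodomethyl)carbonyl)amino)methyl on a saturated chain carbon, seven bonds along the chain from a nitrogen on an aromatic ring. Within the data shown here, no measured pair shows what this change alone does, and compounds 2 and 3 differ from compound 1 in more than one place, so their numbers give no direct guide. Because compound 1 gives 47% and the change is small, the step is expected to be modest and downward, a number 12 percentage points lower from compound 1 to compound 4 (beyond the scatter). Compound 4 is therefore estimated at 35%, with a likely range from 10% to 60%.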

Compound 4, a percentage reported as inhibition, at one concentration (the size of the read-out at that concentration, not a potency): 20%
Estimate against measurement, compound 4: 15 percentage points above, and the stated range covers the measured number.
By their numbers in this assay, from the lowest: compounds 2 and 3 (each within the scatter of the next); then compound 4; then compound 1.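

Among these compounds, this is the first pair that differs in one place only, so the change can be read on its own: in this assay, ((iodomethyl)carbonyl)amino in place of (((iodomethyl)carbonyl)amino)methyl on a saturated chain carbon, seven bonds along the chain from a nitrogen on an aromatic ring, gives a number 27 percentage points lower from compound 1 to compound 4 (beyond the scatter). One carbon fewer in the chain thus makes a real difference at this position, although the end group stays the same and compound 4 still gives 20%. Nothing measured here explains the drop.

The compounds shown leave open whether a longer chain than that of compound 1 would give a higher or a lower number. They also leave open how a ((bromomethyl)carbonyl)amino group at the chain end would compare with the iodine-bearing group at either chain length.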